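The source may hold more compounds than are shown below. What is called first, only, known or untested is meant among the compounds shown, and "the series" means these compounds.

Compound 1 `O=C(O)c1cc(-n2ccnc2)ccc1O`: 75 mg/kg
Compound 2 `O=C(O)c1cc(-c2cscn2)ccc1O`: 95 mg/kg
Compound 3 `O=C(O)c1cc(C2N=NN=N2)ccc1O`: 110 mg/kg

These three share a core and differ only in the five-membered ring attached to it. In a functional assay on the whole organism for inhibition, with Rattus norvegicus as the target, read by paw edema (on this read-out higher numbers stand for an effect only at larger amounts of compound and lower numbers for an effect already at smaller amounts), compound 1 gives 75 mg/kg, compound 2 gives 95 mg/kg and compound 3 gives 110 mg/kg. On the numbers shown compound 3 stands at the top of the three, but the steps of a 1.5-fold higher number from compound 1 to compound 3 (0.17 log units; within the scatter) and a 1.2-fold higher number from compound 2 to compound 3 (0.06 log units; within the scatter) both lie within the scatter, as does a 1.3-fold higher number from compound 1 to compound 2 (0.10 log units; within the scatter), so the three cannot be separated on this read-out.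

Compound 4 `O=C(O)c1cc(-n2cccn2)ccc1O` is not yet measured. It differs from compound 3 by a group of 5 heavy atoms (3 carbon, 2 nitrogen; one five-membered aromatic ring with 2 hetero atoms) in place of a group of 5 heavy atoms (1 carbon, 4 nitrogen; one five-membered non-aromatic ring with 4 hetero atoms), on an aromatic carbon. The step bearing on it most directly is the reverse of a 1.5-fold higher number from compound 1 to compound 3 (0.17 log units; within the scatter), with a 1.2-fold higher number from compound 2 to compound 3 (0.06 log units; within the scatter) as a second comparison; both are small and within the scatter. The step expected in this assay is therefore a 1.4-fold lower number from compound 3 to compound 4 (0.14 log units; within the scatter), toward a slightly smaller number, but not beyond the scatter. Compound 4 is estimated at 80 mg/kg, with a range from 45 mg/kg to 140 mg/kg.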

Compound 4, dose for half-maximal effect: 200 mg/kg
Beside the measured number, compound 4's estimate is 2.5-fold (0.40 log units) below it; the measured number lies above the stated range.
By their numbers in this assay, from the lowest: compounds 1, 2, 3 and 4 (each within the scatter of the next, the first and the last beyond it).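

In this assay, the ring at this position is no longer shown to be interchangeable: 1H-pyrazol-1-yl in place of 1H-imidazol-1-yl, a ring with the same count of carbon and nitrogen atoms, gives a 2.7-fold higher number from compound 1 to compound 4 (0.43 log units; beyond the scatter). Against the thiazole of compound 2 the change gives a 2.1-fold higher number from compound 2 to compound 4 (0.32 log units; beyond the scatter), so both steps are modest but, unlike those among the first three compounds, exceed the scatter. Compound 3 remains unresolved from this new end of the series, with a 1.8-fold higher number from compound 3 to compound 4 (0.26 log units; within the scatter).

Going by these compounds, whether an amine or a carboxylic acid on this aromatic carbon, para to the hydroxy group, would fall within the same range remains open. The data shown offer no measurement that accounts for the difference between the two rings.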